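This account rests on a few compounds, and the source may have more. Where it says the series, first, only, none or still open, it means among the compounds named here.

Measured so far:
- compound 1, `COCCNc1nc(NCC2CC2)cc(-c2ccccn2)n1`: 10000 nM
- compound 2, `CNc1nc(NCC2CCCCC2)cc(-c2ccccn2)n1`: 10 nM
- compound 3, `CNc1nc(NCc2ccc(NS(C)(=O)=O)cc2)cc(-c2ccccn2)n1`: 8 nM

All three numbers come from a functional assay on HEK293 cells for agonist activity at G-protein coupled receptor 39 (Mus musculus), read by inositol phosphate accumulation; a lower number here means that less compound is needed, a higher number that more compound is needed for the effect. Compound 1 gives 10000 nM, the highest of the three; compound 2 and compound 3 lie far below it, both beyond the scatter, so compound 1 is clearly the weakest of the measured set. Compound 2 and compound 3 are within the scatter of each other and nothing separates them. Within the data shown here, compound 2 and compound 3 differ from compound 1 in more than one place, so no single step between measured compounds can be read from these values.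

The next compound in the series is compound 4, `CC(C)(C)CNc1nc(NCC2CC2)cc(-c2ccccn2)n1`. It differs from compound 1 in one place:
tert-butyl in place of methoxymethyl on a saturated chain carbon bound to a nitrogen on an aromatic ring

Among the measured compounds shown here, with no measured step for this change, the expectation rests on the spread alone. Compound 2 and compound 3 show that a small alkyl on this nitrogen is compatible with low numbers, but those compounds also carry a different group on the other nitrogen, so they do not isolate the change. The step from compound 1 to compound 4 is expected to be a moderate move toward a lower number, a 3.3-fold lower number from compound 1 to compound 4 (0.52 log units; beyond the scatter), with wide uncertainty. Compound 4 is expected at 3000 nM, within 400 nM to 20000 nM.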

Compound 4, half-maximal effective concentration: 1500 nM
Compound 4: middle estimate off by 2.0-fold (0.30 log units), on the high side; the measured number falls inside the stated range.
By their numbers in this assay, from the lowest: compounds 3 and 2 (each within the scatter of the next); then compound 4; then compound 1.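

In this assay, among these compounds, the replacement of methoxymethyl by tert-butyl on a saturated chain carbon bound to a nitrogen on an aromatic ring gives a 6.7-fold lower number from compound 1 to compound 4 (0.82 log units; beyond the scatter) and is the first single-place step available, showing that the number responds to the group at this position with the rest of the structure held constant. The change takes out the oxygen and its hydrogen-bond acceptor and brings in an all-carbon group with 4 heavy atoms in place of 3, so the acceptor count, the atom count and the branching all change together and this one step cannot separate them. No measured information on the compounds bears on the reason for this shift.

Still open, on these data alone, is which of those differences carries the step: an unbranched pentyl chain or an isobutyl group in the same place would begin to separate branching from chain length, and a 2-hydroxyethyl or 2-aminoethyl group would test other heteroatoms there. Also open, as far as these compounds go, is whether the step keeps its size when the cyclopropylmethyl group elsewhere on the shared core is replaced.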